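A few compounds are considered here, and "the series" means these few. Any claim that something is new, unique, unknown or untested is made for them only; others in the source may bear on it.

Compound 1 `Cc1cc(N2CC[C@@H](C)[C@@H](N(C)c3ncnc4[nH]ccc34)C2)n2ncnc2n1`: 67400 nM
Compound 2 `Cc1cc(N2CC[C@@H](C)[C@@H](N(C)c3ncnc4[nH]ccc34)C2)n2nc(SCc3ccc(F)cc3)nc2n1`: 44300 nM
Compound 3 `CCc1cc(N2CC[C@@H](C)[C@@H](N(C)c3ncnc4[nH]ccc34)C2)n2ncnc2n1`: 82200 nM

In a functional assay on BGC-823 cells (Homo sapiens) for inhibition, read by MTT assay, with a stated time of 72 h (a lower number here means a stronger inhibitor, a higher number a weaker inhibitor), the three numbers sit close together. Compound 2 gives the smallest of them, but the step of a 1.5-fold lower number from compound 1 to compound 2 (0.18 log units; within the scatter) is within the scatter, and compound 3 with 82200 nM is only a little further off, so nothing separates compound 2 from the others.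

Compound 4 `Cc1cc(N2CC[C@@H](C)[C@@H](N(C)c3ncnc4[nH]ccc34)C2)n2nc(SCc3ccc(C(F)(F)F)cc3)nc2n1` differs from compound 2 in one place: trifluoromethyl in place of fluoro on an aromatic carbon. For the measured compounds named here, no measured step touches this part of the molecule. The step of a 1.5-fold lower number from compound 1 to compound 2 (0.18 log units; within the scatter) installed the whole (4-fluorobenzyl)sulfanyl group without moving the number beyond the scatter, and the step of a 1.2-fold higher number from compound 1 to compound 3 (0.09 log units; within the scatter) concerns another position. Compound 4 is therefore expected to show no step beyond the scatter, a 1.0-fold higher number from compound 2 to compound 4 (0.01 log units; within the scatter). The estimate for compound 4 is 45000 nM, with a range from 20000 nM to 100000 nM.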

Compound 4, half-maximal inhibitory concentration: 23300 nM
The estimate for compound 4 lay 1.9-fold (0.29 log units) above the measured number; the measured number falls inside the stated range.
By their numbers in this assay, from the lowest: compounds 4, 2, 1 and 3 (each within the scatter of the next, the first and the last beyond it).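

Trifluoromethyl in place of fluoro on the aromatic carbon gives a 1.9-fold lower number from compound 2 to compound 4 (0.28 log units; within the scatter) in this assay, so this change alone does not separate the two compounds. Measured against the unsubstituted parent, however, the (4-(trifluoromethyl)benzyl)sulfanyl group gives a 2.9-fold lower number from compound 1 to compound 4 (0.46 log units; beyond the scatter), a modest step but the first in this set to pass beyond the scatter, which the (4-fluorobenzyl)sulfanyl group did not do. Nothing available explains this result. The compounds shown leave open how an amine, a carboxylic acid or a methoxy group on that same aromatic carbon would read, and whether a longer chain in place of the sulfanyl link would change the number.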